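The source may hold more compounds than are shown below. What is called first, only, known or untested is meant among the compounds shown, and "the series" means these compounds.

Compounds measured so far:
- compound 1, `O=C(Nc1cccc(-n2cc(-c3ccncc3)c(-c3ccc(Cl)c(O)c3)n2)c1)Nc1cccc(C(F)(F)F)c1`: > 32500 nM in a functional assay on MDA-MB-468 cells (Homo sapiens) for inhibition, read by sulforhodamine B assay, with a stated time of 48 h; on this read-out higher numbers stand for lower toxicity in this test and lower numbers for higher toxicity in this test
- compound 2, `COc1cc(-c2nn(-c3cccc(NC(=O)Nc4ccc(Cl)c(C(F)(F)F)c4)c3)cc2-c2ccncc2)ccc1Cl`: > 32500 nM

Both values shown are limits of the assay rather than numbers. Compound 2 reaches only the limit > 32500 nM in this assay. Compound 1 likewise gives only the limit > 32500 nM in this assay. Compound 2 therefore stands where the other value stands too, as summed up in the limit of > 32500 nM in this assay, at which 2 of the 2 values shown sit. Neither compound shows measurable toxicity toward these breast cancer cells within the range tested.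

Compound 3, `O=C(Nc1cccc(-n2cc(-c3ccncc3)c(-c3ccc(Cl)c(O)c3)n2)c1)Nc1ccc(Cl)c(C(F)(F)F)c1`, has not been measured in this assay. It differs from compound 2 in one place: hydrogen in place of methyl on an oxygen on an aromatic ring, so that the methoxy group of compound 2 becomes a hydroxy group, giving a 4-chloro-3-hydroxyphenyl group in place of the 4-chloro-3-methoxyphenyl group. The urea part stays as in compound 2. Compound 1 already carries the hydroxy group and sits at the limit too, so there is no reason to expect a step beyond the scatter in this assay.

Compound 3 is expected to give about 45000 nM in this assay, within 15000 nM to 130000 nM, and most likely again only a limit. The expected step from compound 2 to compound 3 is a step that the limit leaves unreadable from compound 2 to compound 3, essentially none.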

Compound 3, concentration lethal to 50% of the cells: > 32500 nM
Compound 3: only a limit was reported; the forecaster's own chance of this, stated with the estimate: 75%; the middle value lies beyond the limit too.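

Compound 3 gives only a limit, as do compound 1 and compound 2, so the steps from compound 2 to compound 3 and from compound 1 to compound 3 cannot be read in this assay: the limit of > 32500 nM in this assay, at which 3 of the 3 values shown sit.

The compounds shown leave open how far the toxicity of any of the three lies beyond that limit, and whether either structural change alters it.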